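The source may hold more compounds than are shown below. What is called first, only, known or untested is meant among the compounds shown, and "the series" means these compounds.

Compound 1, `O=C(N/N=C/c1c(-c2cc3ccc(Br)cc3oc2=O)[nH]c2ccccc12)c1ccc(Cl)cc1`: 71400 nM
Compound 2, `O=C(N/N=C/c1c(-c2cc3ccc(Br)cc3oc2=O)[nH]c2ccccc12)c1cccc(Br)c1`: > 200000 nM

Of the compounds shown here, two with a shared core have been measured in a toxicity assay on Vero cells (Chlorocebus sabaeus) for inhibition, read by MTT assay, with a stated time of 48 h; a higher number here means a weaker inhibitor, a lower number a stronger inhibitor. Compound 1, `O=C(N/N=C/c1c(-c2cc3ccc(Br)cc3oc2=O)[nH]c2ccccc12)c1ccc(Cl)cc1`, gives 71400 nM. Compound 2, `O=C(N/N=C/c1c(-c2cc3ccc(Br)cc3oc2=O)[nH]c2ccccc12)c1cccc(Br)c1`, is reported only as a limit of the assay, > 200000 nM. That value is the limit of > 200000 nM in this assay, at which 1 of the 2 values shown sits, so compound 2 stands at the edge of what this assay reports, with no exact number attached. For the measured compounds named here, the single measured step between the two is an at least 2.8-fold higher number from compound 1 to compound 2 (0.44 log units; beyond the scatter).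

Compound 3, `O=C(N/N=C/c1c(-c2cc3ccc(Br)cc3oc2=O)[nH]c2ccccc12)c1ccc(Cl)cc1F`, has not yet been measured in this assay. It differs from compound 2 by 4-chloro-2-fluorophenyl in place of 3-bromophenyl on a carbonyl carbon. Going by the values given here, the one measured step that bears on this change is the earlier swap of the ring on the carbonyl carbon, an at least 2.8-fold higher number from compound 1 to compound 2 (0.44 log units; beyond the scatter), and compound 3 carries a 4-chloro-2-fluorophenyl rather than the 3-bromophenyl of compound 2, placing it closer to the 4-chlorophenyl of compound 1. The step of an at least 2.0-fold lower number from compound 2 to compound 3 (0.30 log units; that floor lies within the scatter) is therefore expected to run back toward the number seen for compound 1, though its size is uncertain since compound 2 gives only a limit. Compound 3 is expected to give about 100000 nM, within a range from 40000 nM to 250000 nM.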

Compound 3, half-maximal inhibitory concentration: < 25000 nM
Compound 3: only a limit was reported; the forecaster's own chance of this, stated with the estimate: 35%; at least 4.0-fold (0.60 log units) between middle value and limit.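

Compound 3 is reported in this assay only as a limit: the limit of < 25000 nM in this assay, at which 1 of the 3 values shown sits.

Even so, the result gives the first step shown towards a lower number: with the 4-chloro group kept, fluoro in place of hydrogen on an aromatic carbon gives an at least 2.8-fold lower number from compound 1 to compound 3 (0.45 log units; beyond the scatter). For the compounds shown here, the ring on the carbonyl carbon can therefore move the number in either direction, since the only earlier step had gone up, and here a single added fluorine is enough to take it beyond the scatter. The change from 3-bromophenyl to 4-chloro-2-fluorophenyl, an at least 8.0-fold lower number from compound 2 to compound 3 (0.90 log units; beyond the scatter), spans the widest gap seen among these three compounds, which differ only in this ring.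

As far as these compounds go, since compound 2 and compound 3 are both reported as limits, the true sizes of these steps stay open, and so does how far the number falls for compound 3. Also open, from the compounds shown here alone, is what an amine, a carboxylic acid or a longer chain on this ring would do to the number, and whether the fluoro group lowers it on other rings too.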